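Cyclohexyl in place of furan-2-yl on an ester

This account rests on a few compounds, and the source may have more. Where it says the series, first, only, none or still open, it means among the compounds named here.

Compound 1 `O=C(NC1CCC(CN2CCN(c3cc(=O)c4cc(C(F)(F)F)cc([N+](=O)[O-])c4s3)CC2)CC1)c1ccccc1` gives 92.9%
Compound 2 `CC(=O)OC1CCC(CN2CCN(c3cc(=O)c4cc(C(F)(F)F)cc([N+](=O)[O-])c4s3)CC2)CC1` gives 0%
Compound 3 `O=C(OC1CCC(CN2CCN(c3cc(=O)c4cc(C(F)(F)F)cc([N+](=O)[O-])c4s3)CC2)CC1)c1ccco1` gives 1%

These values come from an ADME assay on cells (Hepatocyte, Homo sapiens) for metabolic stability, with a stated time of 30 min (on this read-out higher numbers stand for a more stable compound and lower numbers for a less stable compound), and the three compounds share one core. Compound 3 stands level with compound 2 and far from compound 1, the only amide of the three. Compound 4 `O=C(OC1CCC(CN2CCN(c3cc(=O)c4cc(C(F)(F)F)cc([N+](=O)[O-])c4s3)CC2)CC1)C1CCCCC1` differs from compound 3 as follows: cyclohexyl in place of furan-2-yl on a carbonyl carbon. The closest measured evidence is a number 1 percentage points higher from compound 2 to compound 3 (within the scatter) as furan-2-yl replaces methyl on that same carbonyl carbon, and this step stays within the scatter. The large steps of a number 92.9 percentage points lower from compound 1 to compound 2 (beyond the scatter) and a number 91.9 percentage points lower from compound 1 to compound 3 (beyond the scatter) both remove benzamido, a change that compound 4 does not reverse, since it keeps the ester of compound 3. The expected move is therefore small, upward if anything, and the estimate is a step of a number 4 percentage points higher from compound 3 to compound 4 (within the scatter) with none beyond the scatter expected. The expected value for compound 4 is estimated at 5% within a range from 0% to 20% in this measurement.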

Compound 4, percent of the compound remaining: 2.8%
Beside the measured number, compound 4's estimate is 2.2 percentage points above it; measured number inside the range.
By their numbers in this assay, from the lowest: compounds 2, 3 and 4 (each within the scatter of the next); then compound 1.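

In this assay the ester now carries a saturated carbon ring on its carbonyl carbon, and the reading stays flat: with cyclohexyl in place of furan-2-yl the step is a number 1.8 percentage points higher from compound 3 to compound 4 (within the scatter) and with cyclohexyl in place of methyl it is a number 2.8 percentage points higher from compound 2 to compound 4 (within the scatter) on the same carbon. Methyl, furan-2-yl and cyclohexyl at this position therefore give readings within the scatter of one another, whether the group is a ring or not, aromatic or not. The gap to the amide also holds for this third ester, with a number 90.1 percentage points lower from compound 1 to compound 4 (beyond the scatter) for (cyclohexylcarbonyl)oxy in place of benzamido.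

As far as these compounds go, it remains open whether a cyclohexylcarbonylamino group would keep the reading of compound 1, or whether an ester bearing an amine or a carboxylic acid on a longer chain would differ from these three. Nothing shown gives a reason for the flat readings among the esters or for their gap to the amide.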